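Nitro in place of fluoro on compound 1

The compounds below may be only part of what the source reports. "The series", "measured", "known", "first", "only" and "open" are said of these compounds alone.

Measured in a functional assay on CCRF-CEM cells (Homo sapiens) for cytotoxicity, in the presence of a further agent that is not named here; a higher number here means a weaker inhibitor, a lower number a stronger inhibitor:
Compound 1 `Nc1nc(N)c(CCCN(Cc2ccc(NC(CCC(=O)O)C(=O)O)cc2)c2ccc([N+](=O)[O-])c(F)c2F)c(O)n1` gives > 100000 nM as a limit
Compound 2 `Nc1nc(N)c(CCCN(Cc2ccc(NC(CCC(=O)O)C(=O)O)cc2)c2cc(F)ccc2[N+](=O)[O-])c(O)n1` gives > 100000 nM as a limit
Compound 3 `COC(=O)c1ccc(CN(CCCc2c(N)nc(N)nc2O)c2ccc([N+](=O)[O-])c(F)c2F)cc1` gives 45000 nM as a number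

Compound 1 (> 100000 nM) stands at a limit of this assay and has no number of its own. Compound 4 `Nc1nc(N)c(CCCN(Cc2ccc(NC(CCC(=O)O)C(=O)O)cc2)c2ccc([N+](=O)[O-])c(F)c2[N+](=O)[O-])c(O)n1` differs from it in one place, with nitro in place of fluoro on an aromatic carbon, ortho to a fluoro group and meta to a nitro group (nitro in place of fluoro on an aromatic carbon). For the measured compounds named here, no measured step makes this exchange. The closest, a change of the group on the amine nitrogen, is a step that the two limits leave unreadable from compound 1 to compound 2 and gives no size. Going by the values given here, the only readable step is an at least 2.2-fold lower number from compound 1 to compound 3 (0.34 log units; beyond the scatter) but it replaces the (1,3-dicarboxypropyl)amino group, which compound 4 keeps. The compounds that carry that group rest at the limit of > 100000 nM in this assay, at which 2 of the 3 values shown sit, without a number. What is therefore expected in this assay is a number no higher from compound 1 to compound 4 (the limit leaves the size open) and no step beyond the scatter. The estimate for compound 4 is 100000 nM (expected range 50000 nM to 200000 nM), most likely reported as a limit again.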

Compound 4, half-maximal inhibitory concentration: 36000 nM
The estimate for compound 4 lay 2.8-fold (0.44 log units) above the measured number; the whole stated range lies above it.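

In this assay, nitro in place of fluoro on the aromatic carbon ortho to a fluoro group and meta to a nitro group gives an at least 2.7-fold lower number from compound 1 to compound 4 (0.44 log units; beyond the scatter), so a change at this one position is enough to move the number. Compound 4 stands at 36000 nM. It is the only compound shown that keeps the (1,3-dicarboxypropyl)amino group and has a number rather than a limit, so that group does not by itself hold a compound at the limit. The full size of the step stays unread because compound 1 has only a limit: the limit of > 100000 nM in this assay, at which 2 of the 4 values shown sit.

With only fluoro and nitro shown on this carbon, it remains open whether an amine, a nitrile or a chloro group there would move the number as well. From the compounds shown here alone, it is also open whether the same exchange would do so in a compound carrying the methoxycarbonyl group.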